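Methoxy to Methyl, Repeated on a Second Core

The compounds below may be only part of what the source reports. "The series", "measured", "known", "first", "only" and "open" are said of these compounds alone.

Compound 1 `COc1ccc(-c2nnc(COc3ccc(C#N)cc3OC)o2)cc1` and compound 2 `COc1cc(C#N)ccc1OCc1nnc(-c2ccc(C)cc2)o1` share one core and differ only by methyl in place of methoxy on an aromatic carbon. In a functional assay on MCF7 cells (Homo sapiens) for cytotoxicity, read by MTT assay, with a stated time of 48 h (a lower number here means a stronger inhibitor, a higher number a weaker inhibitor), compound 1 gives 11100 nM, while compound 2 gives 27100 nM, so this change produced a 2.4-fold higher number from compound 1 to compound 2 (0.39 log units; beyond the scatter). Compound 3 `COc1ccc(-c2nnc(COc3ccc(-c4nnco4)cc3)o2)cc1` rests on a different core; the difference between the two cores is not broken down here. In this assay compound 3 gives 31200 nM. Compound 4 `Cc1ccc(-c2nnc(COc3ccc(-c4nnco4)cc3)o2)cc1` has not been measured and differs from compound 3 by methyl in place of methoxy on an aromatic carbon, the same change at the same place as seen before. Because the earlier step of a 2.4-fold higher number from compound 1 to compound 2 (0.39 log units; beyond the scatter) pointed toward a weaker inhibitor, a step of similar size is expected here, namely a 2.2-fold higher number from compound 3 to compound 4 (0.35 log units; beyond the scatter). Going by the values given here, only one earlier pair supports this, so the range is wide. Compound 4 is therefore estimated at 70000 nM in this assay.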

Compound 4, half-maximal inhibitory concentration: > 50000 nM
Compound 4: only a limit was reported; the forecaster's own chance of this, stated with the estimate: 25%; the middle value lies beyond the limit too.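

Compound 4 gives > 50000 nM in this assay, which is a limit of the assay and not a number. Methyl in place of methoxy on this second core therefore gives an at least 1.6-fold higher number from compound 3 to compound 4 (0.20 log units; that floor lies within the scatter), a result that fits the change carrying over from one core to the other but neither fixes its size nor proves a real loss. Set beside the earlier step, the result reads: the same change on two cores in this assay, a 2.4-fold higher number (0.39 log units; beyond the scatter) from compound 1 to compound 2 and an at least 1.6-fold higher number (0.20 log units; that floor lies within the scatter) from compound 3 to compound 4; the limit leaves it open whether they differ

The compounds shown leave open how an amine, a hydroxyl or a longer chain such as ethoxy would behave on the same aromatic carbon. Going by these compounds alone, they also cover only two cores, so the response of any third core remains unknown.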